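Replacing a methoxycyclohexyl by an oxanyl group: an expectation

This account rests on a few compounds, and the source may have more. Where it says the series, first, only, none or still open, it means among the compounds named here.

Compound 1, `COc1ccc(-c2c(-c3ccc(OC)cc3)n(Cc3ccccc3)c3ncn([C@@H]4CCCC[C@H]4O)c(=N)c23)cc1`, gives > 20000 nM in a functional assay on PC-3M cells (Homo sapiens) for antiproliferative activity, read by microscopy, with a stated time of 24 h (on this read-out lower numbers stand for stronger inhibition and higher numbers for weaker inhibition), which is a limit of the assay rather than a number.
Compound 2, `COc1ccc(-c2c(-c3ccc(OC)cc3)n(Cc3ccccc3)c3ncn([C@H]4CC[C@H](OC)CC4)c(=N)c23)cc1`, gives > 20000 nM in this assay, again a limit of the assay.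
Compound 3, `N=c1c2c(-c3ccccc3)c(-c3ccccc3)n(CC3CCCCC3)c2ncn1CCCO`, gives 27700 nM; 26900 nM (2 entries) in this assay.

Compound 2 therefore stands at the limit of this assay, with no single number of its own. Of the three values shown, two sit at that limit (the limit of > 20000 nM in this assay, at which 2 of the 3 values shown sit), and only compound 3 returns readable numbers, its two entries agreeing with each other (the several entries of compound 3 in this assay, 27700 nM; 26900 nM (2 entries)). Going by the values given here, the one measured step, a step that the two limits leave unreadable from compound 1 to compound 2, has a limit at both ends and cannot be read.

The unmeasured compound 4, `COc1ccc(-c2c(-c3ccc(OC)cc3)n(Cc3ccccc3)c3ncn(C4CCOCC4)c(=N)c23)cc1`, differs from compound 2 in a single place: oxan-4-yl in place of 4-methoxycyclohexyl on an aromatic nitrogen. Among the compounds with values here, no measured step bears on this exchange; the only recorded step runs between two limits and yields no size. Nothing in the shown data points to a shift beyond the usual scatter in either direction, and the most likely outcome is that compound 4 also returns a limit rather than a number. For compound 4 the estimated step is a step that the limit leaves unreadable from compound 2 to compound 4. Compound 4 is thus expected to give 25000 nM in this assay, within a range from 10000 nM to 60000 nM.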

Compound 4, half-maximal inhibitory concentration: > 20000 nM
Compound 4: no number, only a limit; the forecaster's own chance of this, stated with the estimate: 75%; the middle value is on the limit's open side.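

Compound 4 gives > 20000 nM in this assay, which is a limit of the assay and not a number. No step among compound 1, compound 2 and compound 4 can be read, as each stands at a limit: the limit of > 20000 nM in this assay, at which 3 of the 4 values shown sit.

The compounds shown leave open how the 2-hydroxycyclohexyl, 4-methoxycyclohexyl and oxan-4-yl groups on the aromatic nitrogen rank against one another.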